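The compounds below may be only part of what the source reports. "The series", "measured", "known", "first", "only" and "open" are said of these compounds alone.

Three compounds in this set have been run through a physicochemical assay for lipophilicity, measured as octanol-water partition; a lower number here means a more polar compound, a higher number a more lipophilic compound. Compound 3, `Cc1cccc(Cl)c1OCCCO`, carries a 3-hydroxypropyl chain on its aromatic oxygen, and in this assay compound 3 gives 2.93. Compound 2, `Cc1cccc(Cl)c1OCC(C)O`, shares the same core and differs from compound 3 only in the chain: 1-hydroxyethyl in place of 2-hydroxyethyl on a saturated chain carbon bound to an oxygen on an aromatic ring. In this assay compound 2 gives 2.73, so the step of a number 0.20 log units lower from compound 3 to compound 2 (within the scatter) is small and falls inside the ordinary spread of repeated readings of this kind.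

Compound 1, `Cc1cc(OCCCO)cc(C)c1Cl`, has a different core from compound 3, and how the two cores differ is not broken down here. It carries the same 3-hydroxypropyl chain as compound 3, and in this assay compound 1 gives 3.38, the highest of the three measured numbers.

Compound 4, `Cc1cc(OCC(C)O)cc(C)c1Cl`, has not yet been measured. It stands to compound 1 exactly as compound 2 stands to compound 3, with the same change at the same place: 1-hydroxyethyl in place of 2-hydroxyethyl on a saturated chain carbon bound to an oxygen on an aromatic ring. Going by the values given here, only one measured example of this change exists here, and it was a number 0.20 log units lower from compound 3 to compound 2 (within the scatter). Among the compounds with values here, for compound 4 the expected step is a number 0.20 log units lower from compound 1 to compound 4 (within the scatter), about the same size as the earlier one, because the single measured instance of this change was a number 0.20 log units lower from compound 3 to compound 2 (within the scatter) and the starting point is compound 1 at 3.38. Compound 4 is accordingly estimated at 3.18, with four of five repeat readings expected to fall between 2.85 and 3.5.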

Compound 4, partition coefficient: 3.18
For compound 4 middle estimate and measured number coincide at the digits printed; the measured number falls inside the stated range.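

In this assay the change of 2-hydroxyethyl to 1-hydroxyethyl, on a saturated chain carbon bound to an oxygen on an aromatic ring, has now been read on two different cores: the first reading is a number 0.20 log units lower from compound 3 to compound 2 (within the scatter) and the second is a number 0.20 log units lower from compound 1 to compound 4 (within the scatter) on the other core. The two steps print the same size, so in these two pairs the change carried over from one core to the other, and the difference between the cores did not alter the reading of the step. It does not show that the change has a real effect, since each step lies within the scatter and cannot be told apart from the spread of repeat readings; two pairs also make no rule for the whole series, and nothing here gives a reason for the match.

The compounds shown leave open how a chain ending in an amine or a carboxylic acid, or a longer chain, would read in this assay on either core. They also leave open whether this same change would give a step of similar size on any core other than those of compound 1 and compound 3.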